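Lengthening the chain between amide and phenyl ring

A few compounds are considered here, and "the series" means these few. Any claim that something is new, unique, unknown or untested is made for them only; others in the source may bear on it.

Measured so far:
compound 1, `CCCn1c(=O)[nH]c2nc(-c3ccc(OCC(=O)NCCCCc4ccccc4)cc3)[nH]c2c1=O`, 3.3 nM
compound 2, `CCCn1c(=O)[nH]c2nc(-c3ccc(OCC(=O)NCc4ccccc4)cc3)[nH]c2c1=O`, 7 nM

Both were tested in an assay on CHO cells for displacement of a labelled ligand from adenosine receptor A2b (Homo sapiens), read by scintillation counting, with a stated time of 75 min; on this read-out lower numbers stand for stronger inhibition and higher numbers for weaker inhibition. Compound 2 gives the highest of the two numbers, with compound 1 the nearest, a 2.1-fold higher number from compound 1 to compound 2 (0.33 log units; beyond the scatter). Compound 3, `CCCn1c(=O)[nH]c2nc(-c3ccc(OCC(=O)NCCCc4ccccc4)cc3)[nH]c2c1=O`, has not been measured. It differs from compound 2 by phenethyl in place of phenyl on a saturated chain carbon bound to an amide-type nitrogen. Within the data shown here, compound 3 thus sits between compound 2 and compound 1 in chain length, and the only step that bears on it, a 2.1-fold higher number from compound 1 to compound 2 (0.33 log units; beyond the scatter), was modest. Compound 3 is therefore expected to show a small step of a 1.6-fold lower number from compound 2 to compound 3 (0.19 log units; within the scatter), giving an estimated 4.5 nM, with a range from 2 nM to 10 nM.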

Compound 3, inhibition constant: 27.9 nM
Compound 3: the middle estimate sits 6.2-fold (0.79 log units) below what was measured, and the stated range ends below it.
By their numbers in this assay, from the lowest: compound 1; then compound 2; then compound 3.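

The number does not follow chain length steadily at this position: the chain of middle length binds most weakly of the three, with a 4.0-fold higher number from compound 2 to compound 3 (0.60 log units; beyond the scatter) and an 8.5-fold higher number from compound 1 to compound 3 (0.93 log units; beyond the scatter). Lengthening the chain on the amide nitrogen can therefore raise or lower the number, depending on the length reached. Nothing available explains this dip. Still open, on these data alone, is whether a chain longer than that of compound 1 would lower the number further, and whether an amine or a carboxylic acid on the chain's phenyl ring would change the picture.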